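The source may hold more compounds than are shown below. What is called first, only, known or untested is meant among the compounds shown, and "the series" means these compounds.

Measured compounds in an assay on a protein complex for inhibition of NEDD8 activating enzyme (Homo sapiens), read by HTRF, with a stated time of 2 h, in the presence of a further agent that is not named here; a higher number here means a weaker inhibitor, a lower number a stronger inhibitor:

compound 1 `NS(=O)(=O)OC[C@@H]1C[C@@H](n2nnc3c(N[C@H]4CCc5ccccc54)ncnc32)C[C@@H]1O` gives 0.21 nM
compound 3 `NS(=O)(=O)OC[C@@H]1C[C@@H](n2nnc3c(NCc4ccco4)ncnc32)C[C@@H]1O` gives 30.6 nM
compound 2 `NS(=O)(=O)OC[C@@H]1C[C@@H](n2ncc3c(N[C@H]4CCc5ccccc54)ccnc32)C[C@@H]1O` gives > 10000 nM, which is a limit of the assay and not a number.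

Compound 3 holds the highest of the two numbers given; its nearest neighbour is compound 1, and the step of a 150-fold higher number from compound 1 to compound 3 (2.16 log units; beyond the scatter) separates them, beyond the scatter. Of the values shown, one sits at the limit of > 10000 nM in this assay, at which 1 of the 3 values shown sits.

Compound 4 `NS(=O)(=O)OC[C@@H]1C[C@@H](n2nnc3c(NCCCc4ccccc4)ncnc32)C[C@@H]1O` differs from compound 3 by phenethyl in place of furan-2-yl on a saturated chain carbon bound to a nitrogen on an aromatic ring. Going by the values given here, the only measured step on this nitrogen, a 150-fold higher number from compound 1 to compound 3 (2.16 log units; beyond the scatter), exchanges the group on the nitrogen itself and is large; it shows this position to be sensitive but does not reach the change toward 3-phenylpropyl. No listed step bears directly on the furan-to-phenethyl exchange, so the direction is open, and the expected step of a 2.0-fold lower number from compound 3 to compound 4 (0.31 log units; beyond the scatter) is modest, leaning toward a lower number. The estimate for compound 4 in this assay is 15 nM, within 2 nM to 150 nM.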

Compound 4, half-maximal inhibitory concentration: 149 nM
Compound 4: middle estimate off by 9.9-fold (1.00 log units), on the low side; low and high end bracket the measured number.
By their numbers in this assay, from the lowest: compound 1; then compound 3; then compound 4. At a limit, above all of these: compound 2.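

In this assay, replacing (furan-2-yl)methyl with 3-phenylpropyl gives a 4.9-fold higher number from compound 3 to compound 4 (0.69 log units; beyond the scatter), so the nitrogen on the aromatic ring remains sensitive among groups that carry their ring on a chain, and the longer phenyl-bearing group brings no gain over the furan. With a 710-fold higher number from compound 1 to compound 4 (2.85 log units; beyond the scatter), the order on this nitrogen runs from 2,3-dihydro-1H-inden-1-yl in compound 1, through (furan-2-yl)methyl in compound 3, to 3-phenylpropyl in compound 4. No measured property bears on this exchange.

Because the chain and the ring change together from compound 3 to compound 4, the step does not separate their contributions. As far as these compounds go, a benzyl group would keep the phenyl ring on the shorter chain, and how it would rank against compound 3 and compound 4 remains open.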